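The compounds below may be only part of what the source reports. "The series", "measured", "known", "first", "only" and "open" are said of these compounds alone.

Compound 1, `N#C/C(C(=O)c1c[nH]c2ccccc12)=C(\S)Nc1ccccc1`: -28%
Compound 2, `N#C/C(C(=O)c1c[nH]c2ccccc12)=C1/SC(c2ccccc2)=NN1c1ccccc1`: -31%
Compound 3, `CC(=O)c1sc(Nc2ccccc2)c(C#N)c1-c1c[nH]c2ccccc12`: -44.4%

All three were measured in a functional assay on the whole organism (strain Swiss) for inhibition, with Mus musculus as the target, read by paw edema, with a stated time of 4 h, at a dose of 70 mg/kg by the oral route; on this read-out higher numbers stand for more inhibition at the one dose given (going by the name of the read-out) and lower numbers for less inhibition. In this assay compound 1 gives -28% and compound 2 gives -31%; both numbers are negative, so neither compound reduced the swelling at the dose given. Compound 3 gives -44.4%, the lowest of the three numbers. Its nearest neighbour is compound 2, whose number lies higher by a gap beyond the usual scatter, and the gap to compound 1 is larger still. Compound 3 is thus the compound with the least inhibition among those measured, on this read-out.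

Compound 4, `CCC(=O)c1sc(Nc2ccccc2)c(C#N)c1-c1c[nH]c2ccccc12`, has not yet been measured in this assay. It differs from compound 3 in one place: methyl in place of hydrogen on a saturated chain carbon bound to a carbonyl carbon. Going by the values given here, no pair of measured compounds differing in one place is available to show how a change of this kind shifts the read-out, so the expectation rests on compound 3 alone. A small change in a chain is expected to shift the read-out little, if at all: for the step of a number 4.4 percentage points higher from compound 3 to compound 4 (within the scatter) no movement beyond the usual scatter is estimated. Compound 4 is therefore expected to give about -40% in this assay, estimated to fall between -65% and -12%.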

Compound 4, a percentage reported as inhibition, in the whole organism at one dose (the size of the read-out at that dose, not a potency): -14.2%
Compound 4: middle estimate off by 25.8 percentage points, on the low side, and the stated range covers the measured number.
By their numbers in this assay, from the lowest: compound 3; then compounds 2 and 1 (each within the scatter of the next); then compound 4.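

In this assay, going by these compounds alone, the one change that turns acetyl into propanoyl, a methyl in place of hydrogen on a saturated chain carbon bound to a carbonyl carbon, gives a number 30.2 percentage points higher from compound 3 to compound 4 (beyond the scatter). Within the data shown here, this is the first pair in the set that differs in one place, and it shows that this position is sensitive: a single added carbon moves the read-out by a large step, which the earlier compounds, differing from each other in more than one place, could not reveal. Even so, compound 4 stays negative at -14.2%, so the change brings the number closer to zero without showing any reduction of the swelling, and nothing measured here explains why the step is so large.

Going by these compounds, a single step gives no trend, so it remains open whether a longer chain such as butanoyl would raise the number further or lower it again. Also open, on these data alone, is what an amine or a carboxylic acid on the same chain carbon would do, and whether any group there could turn the number positive.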